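Series notes: cyano to phenylsulfonyl on the shared core

The compounds below may be only part of what the source reports. "The series", "measured", "known", "first", "only" and "open" are said of these compounds alone.

Measured so far:
compound 1, `CN(C)/C(=N\C#N)C1=CC(C)(C)Oc2ccc([N+](=O)[O-])cc21`: "nt" (no result reported)
compound 2, `CN(C)/C(=N\C#N)C1=CC(C)(C)Oc2ccc(C#N)cc21`: 73.7%

Compound 1, `CN(C)/C(=N\C#N)C1=CC(C)(C)Oc2ccc([N+](=O)[O-])cc21`, carries a nitro group on the shared core and stands without a number in a functional assay on the whole organism (aorta) with Rattus norvegicus as the target; on this read-out higher numbers stand for larger maximal responses and lower numbers for smaller maximal responses; for compound 1 the entry reads "nt" (no result reported). Among the compounds with values here, compound 2 is therefore the only compound of the series with a value: in this assay compound 2 gives 73.7%. Within the data shown here, with one number and one blank entry, no step between measured compounds can be formed, and nothing shows how a change on this aromatic carbon moves the maximal response.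

Compound 3, `CN(C)/C(=N\C#N)C1=CC(C)(C)Oc2ccc(S(=O)(=O)c3ccccc3)cc21`, is the next compound for this assay. It differs from compound 2 in one place: phenylsulfonyl in place of cyano on an aromatic carbon. The group that enters is considerably larger than the cyano that leaves.

Among the measured compounds shown here, no measured step exists to rest on, so the direction of the change remains open; a moderate fall beyond the usual scatter is taken as the working expectation, the step from compound 2 to compound 3 being expected as a number 13.7 percentage points lower from compound 2 to compound 3 (beyond the scatter). Compound 3 is estimated at 60%, with an expected range from 30% to 90%.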

Compound 3, intrinsic activity: the largest response reached, in percent of the reference agonist's: 73.8%
For compound 3 the middle estimate is 13.8 percentage points below the measured one; the measured number falls inside the stated range.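

In this assay, within the data shown here, the exchange of cyano for phenylsulfonyl on this aromatic carbon gives a number 0.1 percentage points higher from compound 2 to compound 3 (within the scatter), the first step that can be read, and it lies within the scatter. The position thus takes a phenylsulfonyl group of 9 heavy atoms, with its own six-membered aromatic ring, in place of a cyano group of 2 heavy atoms, while the maximal responses of compound 2 and compound 3 stay within the scatter of each other. Nothing at hand bears on why these two maximal responses lie so close.

A single step on one aromatic carbon cannot show whether the maximal response would hold with an amine, a carboxylic acid or a longer alkyl chain at this position, or whether a sulfonyl group with a methyl in place of the phenyl would behave as phenylsulfonyl does. Also open, as far as these compounds go, is how far the maximal response depends on the rest of the shared core, since compound 2 and compound 3 differ only on this aromatic carbon.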